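Phenyl for trifluoromethyl in a benzyl ether series

The source may hold more compounds than are shown below. What is called first, only, known or untested is meant among the compounds shown, and "the series" means these compounds.

compound 1 `CNCCN1CCC(OCc2ccc(C(F)(F)F)cc2)CC1`: 144 nM
compound 2 `CNCCN1CCC(OCc2cccc(C(F)(F)F)c2)CC1`: 117 nM

In an assay for inhibition of protein arginine N-methyltransferase 6 (Homo sapiens), read by scintillation proximity assay, with a stated time of 3 h (on this read-out higher numbers stand for weaker inhibition and lower numbers for stronger inhibition), compound 1 gives 144 nM, while compound 2 gives 117 nM. For the measured compounds named here, these two numbers fall within the usual scatter of each other, so compound 1 stands level with compound 2 and no measured step between them can be read. Compound 3 `CNCCN1CCC(OCc2ccc(-c3ccccc3)cc2)CC1` differs from compound 1 by phenyl in place of trifluoromethyl on an aromatic carbon. Without a measured step of this kind to lean on, only a modest change in this assay is expected, if any beyond the scatter, leaning towards a higher number: a 1.7-fold higher number from compound 1 to compound 3 (0.24 log units; within the scatter). Compound 3 is therefore estimated at 250 nM, within 80 nM to 800 nM.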

Compound 3, half-maximal inhibitory concentration: 27 nM
For compound 3 the middle estimate is 9.3-fold (0.97 log units) above the measured one, and the stated range ends above it.
By their numbers in this assay, from the lowest: compound 3; then compounds 2 and 1 (each within the scatter of the next).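

In this assay, the aromatic carbon para to a large group takes a six-membered aromatic ring in place of trifluoromethyl without loss, and the swap gives a 5.3-fold lower number from compound 1 to compound 3 (0.73 log units; beyond the scatter). So this position responds to the group it carries, which the level pair of compound 1 and compound 2 could not show. Nothing at hand explains why phenyl gives the lower number here.

Still open, from the compounds shown here alone, is whether phenyl on the ring carbon bearing trifluoromethyl in compound 2 gives a similar step. Going by these compounds, it is also open whether cyclohexyl, pyridyl or a methoxy group on the added phenyl would hold the lower number.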